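The source may report more compounds than this note shows. Statements on the series, on what has been measured and on what is new or still open speak of the compounds shown alone.

Of the compounds shown here, two of a shared core have been measured. Compound 1 `O=C1N/C(=C\c2ccc(O)cc2)C(=O)N1c1ccc(I)cc1` gives 25500 nM in a functional assay on NCI-H292 cells (Homo sapiens) for antiproliferative activity; a higher number here means a weaker inhibitor, a lower number a stronger inhibitor. Compound 2 `COc1cccc(N2C(=O)N/C(=C\c3ccc(O)cc3)C2=O)c1` gives in this assay only > 200000 nM, which is a limit of the assay and not a number. Among the values shown, compound 2 therefore stands at the limit of > 200000 nM in this assay, at which 1 of the 2 values shown sits, while compound 1 is the one with a numerical reading.

Compound 3 `O=C1N/C(=C\c2ccc(O)cc2)C(=O)N1c1cccc(I)c1` has not yet been measured in this assay. It differs from compound 2 in one place: iodo in place of methoxy on an aromatic carbon. For the measured compounds named here, no measured pair shows this same exchange, so the size of the step cannot be read from the data and must be guessed. The expectation is that the change in this assay moves toward a stronger inhibitor, though it may also leave compound 3 at a limit. Compound 3 is expected to give 70000 nM, with a range from 20000 nM to 250000 nM. The step is thus estimated as an at least 2.8-fold lower number from compound 2 to compound 3 (0.45 log units; beyond the scatter).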

Compound 3, half-maximal inhibitory concentration: > 200000 nM
Compound 3 gave a limit, no number; the forecaster's own chance of this, stated with the estimate: 35%; middle value at least 2.8-fold (0.45 log units) from the limit.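

Moving the iodine alone separates the two iodo compounds: with 3-iodophenyl in place of 4-iodophenyl on the amide-type nitrogen in the ring, this assay shows an at least 7.8-fold higher number from compound 1 to compound 3 (0.89 log units; beyond the scatter). Iodo on this aromatic ring therefore does not by itself bring the numerical reading of compound 1, since where it sits matters, and iodo placed meta to a large group gives no number, just as methoxy in that place gives none. The step between compound 2 and compound 3 cannot be read, as each of the two values is a limit of the assay and not a number, and the series now gathers at that limit: the limit of > 200000 nM in this assay, at which 2 of the 3 values shown sit.

The compounds shown leave open whether any group in this place gives a numerical reading, as only iodo and methoxy are shown there, and how far past the limit those two compounds lie. Also open, as far as these compounds go, is whether 4-methoxyphenyl would read like 4-iodophenyl, and whether an amine or a carboxylic acid on this ring would bring a number in this assay.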